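A few compounds are considered here, and "the series" means these few. Any claim that something is new, unique, unknown or untested is made for them only; others in the source may bear on it.

Measured in a functional assay on HeLa cells (Homo sapiens) for antiproliferative activity, read by MTT assay, with a stated time of 72 h; a lower number here means a stronger inhibitor, a higher number a weaker inhibitor:
compound 1 `CCCCCc1ccc(C#Cc2cn(CCC(COC(C)=O)COC(C)=O)c(=O)n(C(=O)c3ccccc3)c2=O)cc1` — 79100 nM.
compound 2 `CC(=O)OCC(CCn1cc(C#CC2CC2)c(=O)n(C(=O)c2ccccc2)c1=O)COC(C)=O` — reported only as a limit of the assay, > 100000 nM.
compound 3 `CCCCCC#Cc1cn(CCC(COC(C)=O)COC(C)=O)c(=O)n(C(=O)c2ccccc2)c1=O` — 53700 nM.

Compound 3 has the lowest of the two plain numbers, though its nearest neighbour is close: a 1.5-fold lower number from compound 1 to compound 3 (0.17 log units; within the scatter). Compound 4 `CC(=O)OCC(CCn1cc(C#CCCCCl)c(=O)n(C(=O)c2ccccc2)c1=O)COC(C)=O` differs from compound 3 by chloro in place of ethyl on a saturated chain carbon, three bonds along the chain from a triple-bonded carbon. For the measured compounds named here, no measured step swaps chloro for ethyl anywhere. The steps that did alter the group on the triple bond, a 1.5-fold lower number from compound 1 to compound 3 (0.17 log units; within the scatter) and an at least 1.8-fold lower number from compound 2 to compound 3 (0.27 log units; that floor lies within the scatter), both stayed within the scatter, so a change sitting further out along this chain is expected to move this assay little and in no clear direction. Compound 4 is therefore expected to give 60000 nM, within 25000 nM to 150000 nM. That amounts to an expected step of a 1.1-fold higher number from compound 3 to compound 4 (0.05 log units; within the scatter).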

Compound 4, half-maximal inhibitory concentration: 52800 nM
For compound 4 the middle estimate is 1.1-fold (0.06 log units) above the measured one; the range from low to high includes it.
By their numbers in this assay, from the lowest: compounds 4, 3 and 1 (each within the scatter of the next). At a limit, above all of these: compound 2.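

In this assay, for the compounds shown here, the step at this place on the chain reads a 1.0-fold lower number from compound 3 to compound 4 (0.01 log units; within the scatter) and so, unlike the earlier steps that replaced the whole group on the triple-bonded carbon, it tests chloro in place of ethyl directly and finds no change beyond the scatter. The 3-chloropropyl chain also gives a 1.5-fold lower number from compound 1 to compound 4 (0.18 log units; within the scatter) and an at least 1.8-fold lower number from compound 2 to compound 4 (0.27 log units; that floor lies within the scatter) in the other two comparisons. Compound 2 is reported only as a limit, so that last step is a floor: the limit of > 100000 nM in this assay, at which 1 of the 4 values shown sits.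

As far as these compounds go, whether an amine or a carboxylic acid at this chain end, or a longer chain carrying chloro, would move the number beyond the scatter remains open.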